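Second chloro on the purine core of compound 1

The source may hold more compounds than are shown below. What is called first, only, known or untested is meant among the compounds shown, and "the series" means these compounds.

Compound 1 `ClCc1ccc(Cn2cnc3c(Cl)ncnc32)cc1` is the stronger of the two measured compounds. In a functional assay on TK-10 cells (Homo sapiens) for cytotoxicity, read by sulforhodamine B assay, with a stated time of 48 h (a lower number here means a stronger inhibitor of growth, a higher number a weaker inhibitor of growth), compound 1 gives 1090 nM, while compound 2 `ClCc1ccccc1Cn1cnc2c(Cl)ncnc21` gives 22900 nM in this assay, a gap that lies beyond the scatter. Compound 3 `ClCc1ccc(Cn2cnc3c(Cl)nc(Cl)nc32)cc1` carries the same benzyl arm as compound 1 and differs only by chloro in place of hydrogen on an aromatic carbon, a chloro in place of hydrogen on an aromatic carbon, between two ring nitrogen atoms and meta to the existing chloro group on the fused core. For the measured compounds named here, no measured pair shows this exact change, so its size is not known from the series. The expectation is a step from compound 1 to compound 3 of a 1.3-fold lower number from compound 1 to compound 3 (0.11 log units; within the scatter) in this assay, that is, no clear shift beyond the scatter in either direction. For compound 3 the estimate in this assay is 850 nM, with a range from 250 nM to 3000 nM.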

Compound 3, concentration for 50% growth inhibition: 6610 nM
For compound 3 the middle estimate is 7.8-fold (0.89 log units) below the measured one; measured number outside the range, above it.
By their numbers in this assay, from the lowest: compound 1; then compound 3; then compound 2.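

Placing chloro on the aromatic carbon between two ring nitrogen atoms, with the benzyl arm of compound 1 unchanged, gives a 6.1-fold higher number from compound 1 to compound 3 (0.78 log units; beyond the scatter) in this assay as the first reading at this position. The position is therefore not indifferent to substitution on this core, and here the added chloro goes with weaker growth inhibition. Nothing measured here accounts for the size or direction of this step.

A single substituent on a single benzyl arm cannot separate an effect specific to chloro from one shared by other groups at this position, and an amine or a methoxy group there would test that. On these data alone, whether the same change gives a similar step on the arm of compound 2 also remains open.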